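Trifluoromethyl for Cyano on a Dichloroacetanilide

This account rests on a few compounds, and the source may have more. Where it says the series, first, only, none or still open, it means among the compounds named here.

Compound 3 `N#Cc1cccc(NC(=O)C(Cl)Cl)c1` is the weakest of the two compounds with a number in a functional assay on A549 cells (Homo sapiens) for antiproliferative activity, read by MTT assay, with a stated time of 72 h; a higher number here means a weaker inhibitor, a lower number a stronger inhibitor: compound 3 gives 66500 nM, while compound 2 `O=C(Nc1cccc(Cl)c1)C(Cl)Cl` gives 14800 nM, and compound 1 `O=C(Nc1cccc(F)c1)C(Cl)Cl` is recorded as "not determined" (no result reported) in this assay. Going by the values given here, the one measured step in the set, a 4.5-fold higher number from compound 2 to compound 3 (0.65 log units; beyond the scatter), shows the cyano group weakening inhibition relative to chloro.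

Compound 4 `O=C(Nc1cccc(C(F)(F)F)c1)C(Cl)Cl` differs from compound 3 by trifluoromethyl in place of cyano on an aromatic carbon. Among the compounds with values here, no measured step covers trifluoromethyl directly; the step from chloro to cyano is the only one that bears on it, and it points in one direction only, so the return from cyano toward a halogen-rich group is a loose guide. A modest step toward a lower number in this assay is therefore expected, a 2.7-fold lower number from compound 3 to compound 4 (0.42 log units; beyond the scatter), with wide uncertainty. Compound 4 is estimated at 25000 nM, within the range 8000 nM to 80000 nM.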

Compound 4, half-maximal inhibitory concentration: 12200 nM
For compound 4 the middle estimate is 2.0-fold (0.31 log units) above the measured one, and the stated range covers the measured number.
By their numbers in this assay, from the lowest: compounds 4 and 2 (each within the scatter of the next); then compound 3.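

In this assay, the change from cyano to trifluoromethyl on this aromatic carbon gives a 5.5-fold lower number from compound 3 to compound 4 (0.74 log units; beyond the scatter), so the weakening seen with the nitrile does not extend to every non-halogen replacement of chloro at this position. Trifluoromethyl and chloro are not told apart here, with a 1.2-fold lower number from compound 2 to compound 4 (0.08 log units; within the scatter), which leaves the nitrile as the one group of the three with measured values that stands apart. Nothing given here bears on why the nitrile differs from the other two groups.

As far as these compounds go, it remains open whether an amine, a carboxylic acid or a methoxy group on this carbon would match chloro and trifluoromethyl or fall with the nitrile. From the compounds shown here alone, it is also open whether the same order would hold with these groups on a different carbon of the ring.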